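This account rests on a few compounds, and the source may have more. Where it says the series, first, only, none or still open, it means among the compounds named here.

Values in an ADME assay on HFF cells (Homo sapiens) for cytotoxicity, with a stated time of 8 days; on this read-out lower numbers stand for higher toxicity in this test and higher numbers for lower toxicity in this test:
compound 1 `Nc1nc(N2CCCC2)c2ncn(/C=C3/CC3(CO)CO)c2n1`: > 300000 nM, a limit
compound 2 `CSc1nc(N)nc2c1ncn2/C=C1/CC1(CO)CO`: > 300000 nM, a limit
compound 3 `CCCCCOc1nc(N)nc2c1ncn2/C=C1/CC1(CO)CO`: 259000 nM

Compound 3 is the only one of the three with an actual number. Compound 1 and compound 2 both rest on (the limit of > 300000 nM in this assay, at which 2 of the 3 values shown sit).

Compound 4 `CCCCSc1nc(N)nc2c1ncn2/C=C1/CC1(CO)CO` carries butylsulfanyl in place of pentyloxy on an aromatic carbon.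

The closest measured comparison is an at least 1.1-fold lower number from compound 2 to compound 3 (0.06 log units; that floor lies within the scatter), where pentyloxy replaces methylsulfanyl at the same carbon. The second is an at least 1.1-fold lower number from compound 1 to compound 3 (0.06 log units; that floor lies within the scatter). Neither shows a readable change, so no step beyond the scatter is expected in this assay. The expected change is a 1.0-fold higher number from compound 3 to compound 4 (0.02 log units; within the scatter). For compound 4 the estimate is 270000 nM, with an expected range of 150000 nM to 450000 nM.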

Compound 4, half-maximal cytotoxic concentration: > 300000 nM
Compound 4 ended at the assay's limit; the forecaster's own chance of this, stated with the estimate: 50%; middle value at least 1.1-fold (0.04 log units) away from the limit.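

Within this assay butylsulfanyl in place of pentyloxy on this aromatic carbon gives an at least 1.1-fold higher number from compound 3 to compound 4 (0.06 log units; that floor lies within the scatter) and so no readable change. For the compounds shown here, compound 4, with a longer sulfur-bound chain than compound 2, also ends at a limit, and compound 3 remains the only compound with a number: (the limit of > 300000 nM in this assay, at which 3 of the 4 values shown sit). The steps from compound 1 and compound 2 to compound 4 join two limits and cannot be read.

This step changes the linking atom and the chain together, so the two stay unseparated. Open, going by these compounds, is whether a longer chain on sulfur, an amine or a carboxylic acid at this carbon would give a number.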